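Swapping trifluoromethyl for a bromophenylsulfonylamino group

The source may hold more compounds than are shown below. What is called first, only, known or untested is meant among the compounds shown, and "the series" means these compounds.

Compound 1 `COc1ccc([C@H]2CC(=O)N(c3cccc(N)c3C)C2)cc1OC1CCCC1`: in a functional assay on HEK293 cells (Homo sapiens) for cytotoxicity (on this read-out lower numbers stand for higher toxicity in this test and higher numbers for lower toxicity in this test), compound 1 reaches only a limit, > 10000 nM.
Compound 2 `COc1ccc([C@H]2CC(=O)N(c3ccccc3N)C2)cc1OC1CCCC1`: in this assay compound 2 reaches only a limit, > 10000 nM.
Compound 3 `COc1ccc([C@H]2CC(=O)N(c3cccc(C(F)(F)F)c3)C2)cc1OC1CCCC1`: in this assay compound 3 reaches only a limit, > 10000 nM.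

Compound 3 therefore stands exactly where the other two stand, at the limit of > 10000 nM in this assay, at which 3 of the 3 values shown sit. The two steps leading to it, a step that the two limits leave unreadable from compound 1 to compound 3 and a step that the two limits leave unreadable from compound 2 to compound 3, cannot be sized, since the values on both sides are limits rather than numbers. Nothing in these three results separates them from one another.

Compound 4 `COc1ccc([C@H]2CC(=O)N(c3cccc(NS(=O)(=O)c4cccc(Br)c4)c3)C2)cc1OC1CCCC1` carries a different group on the ring attached to the amide-type nitrogen: ((3-bromophenyl)sulfonyl)amino in place of trifluoromethyl on an aromatic carbon. Within the data shown here, no measured step describes a change of this kind, so there is no basis for expecting a step in this assay of any particular size or direction; the only guidance is that every compound so far has stayed at the limit. Compound 4 is expected to give about 8000 nM, within a range from 2000 nM to 30000 nM, corresponding to an expected step of an at least 1.2-fold lower number from compound 3 to compound 4 (0.09 log units; that floor lies within the scatter).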

Compound 4, half-maximal cytotoxic concentration: > 10000 nM
Compound 4 was reported as a limit (the forecaster's own chance of this, stated with the estimate: 60%); at least 1.2-fold (0.09 log units) between middle value and limit.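

Compound 3 and compound 4 both give only a limit in this assay, so no step between them can be read: the limit of > 10000 nM in this assay, at which 4 of the 4 values shown sit.

Left open is how the four compounds rank in this assay, and whether ((3-bromophenyl)sulfonyl)amino in place of trifluoromethyl changes the result at all.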